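Isobutyl to Isopropyl Across Two Related Cores

The compounds below may be only part of what the source reports. "The series", "measured", "known", "first", "only" and "open" are said of these compounds alone.

Measured compounds:
compound 1, `CC(C)NC(=N)NC(=N)Nc1ccc(C(F)(F)F)cc1`, 4800 nM
compound 2, `CC(C)CNC(=N)NC(=N)Nc1ccc(C(F)(F)F)cc1`, 3100 nM
compound 3, `CC(C)CNC(=N)NC(=N)Nc1ccc(F)c(F)c1`, 42900 nM

In a functional assay on T-24 cells (Homo sapiens) for antiproliferative activity, read by MTT assay, with a stated time of 72 h (a lower number here means a stronger inhibitor, a higher number a weaker inhibitor), compound 2 gives 3100 nM and compound 1 gives 4800 nM, so the change isopropyl in place of isobutyl on an amine nitrogen produced a 1.5-fold higher number from compound 2 to compound 1 (0.19 log units; within the scatter). Compound 3 stands apart from both: in this assay compound 3 gives 42900 nM, a number well beyond the scatter from either of the other two. The difference between the core of compound 3 and the core of compound 2 is not broken down here.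

Compound 4, `CC(C)NC(=N)NC(=N)Nc1ccc(F)c(F)c1`, has not yet been measured in this assay. It relates to compound 3 by the change (isopropyl in place of isobutyl on an amine nitrogen), the same change that leads from compound 2 to compound 1, made on the same place. Since that earlier step was a 1.5-fold higher number from compound 2 to compound 1 (0.19 log units; within the scatter) and lay within the scatter, the expectation is that compound 4 will sit close to compound 3, most likely a little weaker but without any firm direction, and the step from compound 3 to compound 4 is estimated at a 1.4-fold higher number from compound 3 to compound 4 (0.13 log units; within the scatter). Because compound 3 gives 42900 nM, compound 4 is expected to give about 58000 nM, with a plausible span from 25000 nM to 135000 nM.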

Compound 4, half-maximal inhibitory concentration: 45000 nM
Compound 4: middle estimate off by 1.3-fold (0.11 log units), on the high side, within the range that was stated.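

In this assay, the isopropyl-for-isobutyl swap on the amine nitrogen was read a second time, and it gave a 1.0-fold higher number from compound 3 to compound 4 (0.02 log units; within the scatter), which leaves compound 3 and compound 4 indistinguishable. Set beside the first reading of the same swap, on the core of compound 1, the two steps do not differ: the same change on two cores in this assay, a 1.5-fold higher number (0.19 log units; within the scatter) from compound 2 to compound 1 and a 1.0-fold higher number (0.02 log units; within the scatter) from compound 3 to compound 4, 1.5-fold (0.17 log units) apart, within the scatter of two such steps

On these two cores, then, the swap carried over in the sense that neither step could be told from the scatter, so isobutyl and isopropyl were interchangeable at this place on both; this is agreement between two small steps, which shows neither a real effect of the swap that repeats nor a rule for any core beyond these two.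

The compounds shown leave open whether a larger departure from these two branched groups on the same amine nitrogen, such as a longer chain, a chain ending in an amine or a chain ending in a carboxylic acid, would register at all in this cell assay. They also leave open whether the swap would stay as small on a core bearing a nitrile or a methoxy group in place of the trifluoromethyl group or the fluorine atoms.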